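Replacing a sulfamoylphenyl urea end with a methoxy-trifluoromethylphenyl

The compounds below may be only part of what the source reports. "The series", "measured", "known", "first", "only" and "open" are said of these compounds alone.

Of the compounds shown here, three sharing one core have been tested in a functional assay on MDA-MB-231 cells (Homo sapiens) for antiproliferative activity, read by MTT assay, with a stated time of 72 h; on this read-out higher numbers stand for weaker inhibition and lower numbers for stronger inhibition. Compound 1 `CC(=O)Nc1ccc(S(=O)(=O)Nc2cccc(-c3nc(-c4ccc(NC(=O)c5cccnc5)cc4)no3)c2)cc1` gives 5200 nM, and compound 2 `CCNC(=O)Nc1ccc(S(=O)(=O)Nc2cccc(-c3nc(-c4ccc(NC(=O)c5cccnc5)cc4Cl)no3)c2)cc1` gives 3100 nM. Compound 3 `NS(=O)(=O)c1ccc(NC(=O)Nc2cccc(-c3nc(-c4ccc(NC(=O)c5cccnc5)cc4Cl)no3)c2)cc1` carries a urea in place of the sulfonamide link of the other two, and in this assay compound 3 reaches only the limit of > 10000 nM, a boundary of the measurement rather than a number; its position is recorded as the limit of > 10000 nM in this assay, at which 1 of the 3 values shown sits. Compound 3 therefore stands at the weak end of what has been measured, with no exact value.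

Compound 4 `COc1ccc(NC(=O)Nc2cccc(-c3nc(-c4ccc(NC(=O)c5cccnc5)cc4Cl)no3)c2)cc1C(F)(F)F` keeps the urea of compound 3 and changes its outer group: 4-methoxy-3-(trifluoromethyl)phenyl in place of 4-sulfamoylphenyl on an amide-type nitrogen. Among the compounds with values here, no measured pair in this set shows this change, so its size is an expectation only. Compound 4 is expected to move toward stronger inhibition, a step of an at least 3.3-fold lower number from compound 3 to compound 4 (0.52 log units; beyond the scatter), since even the limit of compound 3 leaves room below it. Compound 4 is estimated at 3000 nM in this assay, within a range from 800 nM to 12000 nM.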

Compound 4, half-maximal inhibitory concentration: 1700 nM
Compound 4: middle estimate off by 1.8-fold (0.25 log units), on the high side; measured number inside the range.
By their numbers in this assay, from the lowest: compounds 4, 2 and 1 (each within the scatter of the next, the first and the last beyond it). At a limit, above all of these: compound 3.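

In this assay, the change of 4-sulfamoylphenyl to 4-methoxy-3-(trifluoromethyl)phenyl on an amide-type nitrogen gives an at least 5.8-fold lower number from compound 3 to compound 4 (0.76 log units; beyond the scatter). Within the data shown here, this is the first comparison here between compounds that differ in one place, and it shows that the outer group on the urea alone can separate a compound with a measurable number from one without. Compound 3 has only a limit and not a number, so the step has a floor but no known full size: the limit of > 10000 nM in this assay, at which 1 of the 4 values shown sits.

The change swaps a whole group, so the compounds shown cannot tell how much the methoxy and the trifluoromethyl each contribute. A plain phenyl, a 4-methoxyphenyl or a 3-(trifluoromethyl)phenyl at this place would begin to separate these parts.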